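Replacing bromo with hydrogen on compound 3

The source may hold more compounds than are shown below. What is called first, only, known or untested is meant among the compounds shown, and "the series" means these compounds.

Of the compounds shown here, three have been read so far in a functional assay on MCF7 cells (Homo sapiens) for cytotoxicity, read by sulforhodamine B assay, with a stated time of 48 h (on this read-out lower numbers stand for stronger inhibition and higher numbers for weaker inhibition), and give the starting picture. Compound 1 `C=CCOc1cc(Br)ccc1C(=O)c1cccnc1` gives > 100000 nM as a limit of the assay and not a number. Compound 2 `O=C(c1cccnc1)c1ccccc1O` gives 24600 nM as a measured number. Compound 3 `C=CCOc1ccc(Br)cc1C(=O)c1cccnc1` gives 92000 nM and so holds the higher of the two measured numbers, with compound 2 lower by a gap beyond the scatter.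

Compound 4 `C=CCOc1ccccc1C(=O)c1cccnc1` differs from compound 3 by hydrogen in place of bromo on an aromatic carbon and keeps the allyloxy group, para to the changed carbon. Going by the values given here, no measured pair isolates this change, so the size of the step remains a judgement based on few numbers. In this assay a small step towards a lower number is expected, near the edge of the scatter, and compound 2 at 24600 nM marks a lower reference that compound 4 is not expected to pass. The estimated change is a 1.5-fold lower number from compound 3 to compound 4 (0.19 log units; within the scatter) in size, with no firm support from a matched pair. A result given only as a limit also remains possible for compound 4. Compound 4 is estimated at 60000 nM with an expected range from 30000 nM to 100000 nM on this read-out.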

Compound 4, half-maximal inhibitory concentration: > 100000 nM
Compound 4 was reported as a limit (the forecaster's own chance of this, stated with the estimate: 25%); at least 1.6-fold (0.22 log units) between middle value and limit.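

In this assay compound 4 gives > 100000 nM, which is a limit of the assay and not a number. Going by these compounds alone, replacing bromo with hydrogen on the aromatic carbon para to the allyloxy group gives an at least 1.0-fold higher number from compound 3 to compound 4 (0.03 log units; that floor lies within the scatter), so this change shows no lower number and its floor does not establish a shift at this position, while the step that shares this change but starts from the other bromo compound, compound 1, cannot be read because both ends are limits: the limit of > 100000 nM in this assay, at which 2 of the 4 values shown sit. The new matched pair without bromo gives an at least 4.0-fold higher number from compound 2 to compound 4 (0.60 log units; beyond the scatter) for allyl in place of hydrogen on the oxygen, the first readable step beyond the scatter, and it runs towards weaker inhibition.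

How far compound 3 and compound 4 truly differ stays unresolved, since the true value of compound 4 lies beyond what this read-out reports. Also open, from the compounds shown here alone, is whether a shorter or longer chain on the oxygen, or an amine or carboxylic acid at the end of that chain, would keep the number nearer compound 2, and whether bromo on the shared core matters once the oxygen carries hydrogen.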